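This account rests on a few compounds, and the source may have more. Where it says the series, first, only, none or still open, it means among the compounds named here.

Measured so far, all in a functional assay on A549 cells (Homo sapiens) for antiproliferative activity, read by MTT assay, with a stated time of 72 h; a lower number here means a stronger inhibitor, a higher number a weaker inhibitor: compound 1 `COc1cc(C(=O)c2sc3ccccc3c2-c2ccccc2)cc(OC)c1OC` gives 5000 nM; compound 2 `COc1cc(C(=O)c2sc3ccccc3c2-c2ccc(F)cc2)cc(OC)c1OC` gives 3200 nM; compound 3 `COc1cc(C(=O)c2sc3ccccc3c2-c2ccc(Cl)cc2)cc(OC)c1OC` gives 7500 nM.

Compound 3 carries the highest of the three numbers: against compound 1 it is within the scatter (a 1.5-fold higher number from compound 1 to compound 3 (0.18 log units; within the scatter)), against compound 2 beyond it (a 2.3-fold higher number from compound 2 to compound 3 (0.37 log units; beyond the scatter)). Compound 4 `COc1ccc(-c2c(C(=O)c3cc(OC)c(OC)c(OC)c3)sc3ccccc23)cc1` differs from compound 3 by methoxy in place of chloro on an aromatic carbon, that is 4-chlorophenyl to 4-methoxyphenyl. For the measured compounds named here, no measured step involves a methoxy; the steps that bear on this carbon are a 1.6-fold lower number from compound 1 to compound 2 (0.19 log units; within the scatter) and a 1.5-fold higher number from compound 1 to compound 3 (0.18 log units; within the scatter), both within the scatter, and a 2.3-fold higher number from compound 2 to compound 3 (0.37 log units; beyond the scatter), modest. Changes at this carbon have moved the number little so far, so the step to compound 4 is expected to be small, a 1.7-fold lower number from compound 3 to compound 4 (0.22 log units; within the scatter). Compound 4 is estimated at 4500 nM, range 1500 nM to 13000 nM.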

Compound 4, half-maximal inhibitory concentration: 4400 nM
For compound 4 the middle estimate is 1.0-fold (0.01 log units) above the measured one; low and high end bracket the measured number.
By their numbers in this assay, from the lowest: compounds 2, 4, 1 and 3 (each within the scatter of the next, the first and the last beyond it).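

In this assay, for the compounds shown here, methoxy on this carbon, the first group here with a hydrogen-bond acceptor by count, stays within the scatter of all three earlier compounds (a 1.7-fold lower number from compound 3 to compound 4 (0.23 log units; within the scatter); a 1.4-fold higher number from compound 2 to compound 4 (0.14 log units; within the scatter); a 1.1-fold lower number from compound 1 to compound 4 (0.06 log units; within the scatter)). Going by these compounds alone, the 4-methoxyphenyl therefore cannot be told apart from the phenyl, 4-fluorophenyl or 4-chlorophenyl, and chloro in place of fluoro remains the only step at this carbon beyond the scatter. Nothing on hand explains this narrow spread.

From the compounds shown here alone, whether an amine, a carboxylic acid or a longer chain on this carbon would move the number further stays open. So does the effect of any change elsewhere on the shared core.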